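A ring swap on the shared core

The source may report more compounds than this note shows. Statements on the series, on what has been measured and on what is new or still open speak of the compounds shown alone.

Compound 2 `Cc1cc(C)c(CN2CCc3c(Cl)cc([C@@H](CO)[C@@H]4CCCO4)c(Cl)c3C2=O)c(=O)[nH]1` stands at the higher of the two numbers in hand: in an assay on cells for inhibition of histone-lysine N-methyltransferase EZH2 (Homo sapiens), read by ELISA, with a stated time of 72 h (on this read-out lower numbers stand for stronger inhibition and higher numbers for weaker inhibition), compound 2 gives 1570 nM, whereas compound 1 `COc1cc(C)[nH]c(=O)c1CN1CCc2c(Cl)cc(-c3c(C)noc3C)c(Cl)c2C1=O` gives 8 nM, a gap well beyond the scatter. Compound 3 `Cc1cc(C)c(CN2CCc3c(Cl)cc(-c4c(C)noc4C)c(Cl)c3C2=O)c(=O)[nH]1` differs from compound 2 in one place: a group of 7 heavy atoms (5 carbon, 1 nitrogen, 1 oxygen; one five-membered aromatic ring with 2 hetero atoms) in place of a group of 8 heavy atoms (6 carbon, 2 oxygen; one five-membered non-aromatic ring with 1 hetero atom), on an aromatic carbon. Within the data shown here, the entering group is the one that compound 1 carries on the same carbon, so a large step toward lower numbers is expected rather than a change within the scatter. Compound 3 is therefore expected to give about 15 nM in this assay, within 5 nM to 60 nM. That estimate implies a step of a 100-fold lower number from compound 2 to compound 3 (2.02 log units; beyond the scatter).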

Compound 3, half-maximal inhibitory concentration: 17 nM
Compound 3: the middle estimate sits 1.1-fold (0.05 log units) below what was measured; low and high end bracket the measured number.
By their numbers in this assay, from the lowest: compound 1; then compound 3; then compound 2.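

Taken alone, the swap to 3,5-dimethyl-1,2-oxazol-4-yl on this aromatic carbon produces a large change in this assay (a 92-fold lower number from compound 2 to compound 3 (1.97 log units; beyond the scatter)). With that group held in place, methyl in place of methoxy on an aromatic carbon produces only a modest change (a 2.1-fold higher number from compound 1 to compound 3 (0.33 log units; beyond the scatter)). Nothing measured here explains either step.

The compounds shown leave open whether the aromatic ring itself or its two methyl groups carry the large step. They also leave open how a phenyl or pyridine ring would behave on the same carbon.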